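Epimer at the hydroxyl-bearing carbon in a sulfonamide series

A few compounds are considered here, and "the series" means these few. Any claim that something is new, unique, unknown or untested is made for them only; others in the source may bear on it.

Measured compounds:
Compound 1, `CC(C)CC1n2cncc2CN(Cc2ccc(OC(F)(F)F)cc2)S1(=O)=O`, 544 nM
Compound 2, `C[C@@H](c1ccc(Cl)cc1)N1Cc2cncn2C(C[C@@H](O)c2ccccc2)S1(=O)=O`, 234 nM

In an assay on cells for inhibition of cytochrome P450 11B1, mitochondrial (Homo sapiens) (a higher number here means a weaker inhibitor, a lower number a stronger inhibitor), compound 2 gives 234 nM, the lower of the two numbers. Its nearest neighbour is compound 1, which in this assay gives 544 nM; the gap between the two lies beyond the usual scatter, so compound 2 stands as the stronger inhibitor of the pair.

Compound 3, `C[C@@H](c1ccc(Cl)cc1)N1Cc2cncn2C(C[C@H](O)c2ccccc2)S1(=O)=O`, has not been measured. It differs from compound 2 as follows: the two compounds have the same atoms and bonds; at least one stereo element is drawn with a configuration in one of them and without one in the other: 1 of 3 stereo elements differ; a stereocentre at a saturated chain carbon is drawn R in compound 2 and S in compound 3. Nothing else changes. Among the compounds with values here, no pair of measured compounds differing only in the configuration of that stereocentre exists here, so the size and direction of this step are unknown from the data. A change at one stereocentre can shift the value in either direction or leave it within the scatter.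

Compound 3 is expected to give 450 nM in this assay, within a range of 100 nM to 2500 nM. The estimated step from compound 2 to compound 3 is a 1.9-fold higher number from compound 2 to compound 3 (0.28 log units; within the scatter), leaning toward a weaker value with wide uncertainty.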

Compound 3, half-maximal inhibitory concentration: 182 nM
Estimate against measurement, compound 3: 2.5-fold (0.39 log units) above; the measured number falls inside the stated range.
By their numbers in this assay, from the lowest: compounds 3 and 2 (each within the scatter of the next); then compound 1.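

In this assay, inverting the hydroxyl-bearing chain carbon from R in compound 2 to S in compound 3 gives a 1.3-fold lower number from compound 2 to compound 3 (0.11 log units; within the scatter), a step within the usual scatter. Within the data shown here, this is the first direct reading of that stereocentre, since the earlier compounds offered no pair differing only there, and it shows that on this background the two drawn configurations at this carbon cannot be told apart by this measurement, with the rest of the molecule held the same. That reading carries one qualification about how the pair is recorded: the fact that one of compounds 2 and 3 is drawn with a defined configuration and the other without, at the place where they differ

The compounds shown do not say whether this lack of a measurable difference belongs to the hydroxyl group itself, as a carbonyl or an amine at the same carbon would be needed to test that, or whether it would hold with a longer chain in place of the present one. They also leave open what inverting the other drawn stereocentres would do, and whether either epimer would behave the same way on a different substituent at the sulfonamide nitrogen.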